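The source may hold more compounds than are shown below. What is called first, only, known or untested is meant among the compounds shown, and "the series" means these compounds.

Measured so far:
compound 2 `CN(C)C(=O)c1cc2cnc(Nc3ccc(C(=O)NCCCN=C=S)cc3)nc2n1C1CCCC1`: 65.1%
compound 1 `CN(C)C(=O)c1cc2cnc(Nc3ccc(S(=O)(=O)NCCCN=C=S)cc3)nc2n1C1CCCC1`: 41.3%

In a functional assay on NCI-H1299 cells (Homo sapiens) for inhibition, read by CCK-8 assay, with a stated time of 72 h, tested at 1 uM (on this read-out lower numbers stand for a weaker effect and higher numbers for a stronger effect at the one concentration tested), compound 2 gives 65.1%, and compound 1 gives 41.3%. Among the compounds with values here, on these two numbers compound 2 stands highest; the only measured step is a number 23.8 percentage points higher from compound 1 to compound 2 (beyond the scatter), and it concerns the group attached to the aromatic carbon, where the sulfonamide-type group of compound 1 is replaced by the amide-type group of compound 2.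

Compound 3 `CN(C)C(=O)c1cc2cnc(Nc3ccc(C(=O)NCCCCCN=C=S)cc3)nc2n1C1CCCC1` differs from compound 2 in another place: a group of 5 heavy atoms (3 carbon, 1 nitrogen, 1 sulfur; no ring) in place of a group of 3 heavy atoms (1 carbon, 1 nitrogen, 1 sulfur; no ring), on a saturated chain carbon, three bonds along the chain from an amide-type nitrogen. The aromatic carbon and the amide-type group of compound 2 are kept; only the saturated chain between the amide-type nitrogen and the isothiocyanate is altered. Within the data shown here, no measured step touches this chain, so neither the direction nor the size of the effect can be read from the two numbers in hand.

With nothing to draw on, the expectation is a step that stays within the scatter, a number 3.1 percentage points lower from compound 2 to compound 3 (within the scatter). Compound 3 is therefore estimated at 62% in this assay, with a range from 40% to 82% to cover the uncertainty of an untested change.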

Compound 3, a percentage reported as inhibition, at one concentration (the size of the read-out at that concentration, not a potency): 50.3%
Estimate against measurement, compound 3: 11.7 percentage points above, and the stated range covers the measured number.
By their numbers in this assay, from the lowest: compounds 1 and 3 (each within the scatter of the next); then compound 2.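

Working notes on the chain. In this assay, the saturated chain carbon three bonds along the chain from the amide-type nitrogen proves sensitive to change: the group of 5 heavy atoms in place of the group of 3 heavy atoms gives a drop beyond the scatter (a number 14.8 percentage points lower from compound 2 to compound 3 (beyond the scatter)). The gain from the amide-type group is therefore not independent of the chain, since the amide-type group with the group of 5 heavy atoms cannot be separated from the sulfonamide-type group with the group of 3 heavy atoms (a number 9 percentage points higher from compound 1 to compound 3 (within the scatter)). Nothing on hand accounts for the effect of the chain.

The compounds shown leave open how a still longer chain or a chain carrying an ether oxygen would read at this place, and whether the sulfonamide-type group would respond to the same chain change as the amide-type group does. Also open, going by these compounds, is what an acrylamide or a simple amine would give in place of the isothiocyanate at the end of the chain.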